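Swapping a Butoxy for Propargylsulfanyl on an Ester Carbonyl

The source may report more compounds than this note shows. Statements on the series, on what has been measured and on what is new or still open speak of the compounds shown alone.

Going by the values given here, compound 1 `CCCCOC(=O)/C=C(C)/C=C/CC(C)CCCC(C)(C)OC` gives 6.62 in a physicochemical assay for lipophilicity (a lower number here means a more polar compound, a higher number a more lipophilic compound), the highest of the three numbers measured so far. Compound 2 `CCOC(=O)/C=C(C)/C=C/CC(C)CCCC(C)(C)Cl` gives 6.44 in this assay, a number that lies within the scatter of compound 1, so the two cannot be ordered. Compound 3 `CCOC(=O)/C=C(C)/C=C/CC(C)CCC(OC)C(C)(C)OC` gives 4.34 in this assay, well below compound 1. Compound 4 `C#CCSC(=O)/C=C(C)/C=C/CC(C)CCCC(C)(C)OC` has not yet been measured; it differs from compound 1 in one place: propargylsulfanyl in place of butoxy on a carbonyl carbon. Among the compounds with values here, no pair of measured compounds shows this change, so no measured step guides the expectation. Compound 4 is expected to stay close to compound 1, with an estimated step of a number 0.32 log units lower from compound 1 to compound 4 (beyond the scatter) that may fall within the scatter or slightly below it. The estimate for compound 4 in this assay is 6.3, expected between 5.6 and 7.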

Compound 4, partition coefficient: 5.9
Compound 4: middle estimate off by 0.40 log units, on the high side; measured number inside the range.
By their numbers in this assay, from the lowest: compound 3; then compound 4; then compounds 2 and 1 (each within the scatter of the next).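

In this assay, going by these compounds alone, propargylsulfanyl in place of butoxy on a carbonyl carbon gives a number 0.72 log units lower from compound 1 to compound 4 (beyond the scatter), the only measured step at this position. The step shows that the number can respond to what sits on this carbonyl carbon, even though the rest of compound 1 stays the same. Nothing available here explains the step.

From the compounds shown here alone, the change swaps oxygen for sulfur, replaces the butyl chain and adds a triple bond all at once, so the share of each remains open. Butylsulfanyl or propargyloxy on the same carbonyl carbon would help separate these parts, while an amine or a carboxylic acid there remains untested in the compounds shown.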